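The source may report more compounds than this note shows. Statements on the series, on what has been measured and on what is new or still open speak of the compounds shown alone.

In an assay on isolated protein for inhibition of Polyunsaturated fatty acid 5-lipoxygenase (Rattus norvegicus) (on this read-out higher numbers stand for weaker inhibition and lower numbers for stronger inhibition), compound 3 `COCCC1CN(c2ccc(C)cc2)NC1=O` gives 1080 nM, the highest of the two single numbers available: compound 2 `COCCC1CN(c2ccc(Cl)cc2)NC1=O` gives 250 nM, while compound 1 `COCCC1CN(c2ccccc2)NC1=O` gives 480 nM; 10300 nM; 350 nM (3 entries), several entries that do not settle on one number. The step from compound 2 to compound 3 was a 4.3-fold higher number from compound 2 to compound 3 (0.64 log units; beyond the scatter), with methyl in place of chloro. Compound 4 `COCCC1CN(c2ccc(OCc3ccccc3)cc2)NC1=O` differs from compound 3 by benzyloxy in place of methyl on an aromatic carbon. For the measured compounds named here, no measured step exchanges a small substituent for a benzyloxy group, so the one step available says only that this position tolerates change, and the wide spread of compound 1 the several entries of compound 1 in this assay, 480 nM; 10300 nM; 350 nM (3 entries) urges caution. A step of a 2.2-fold lower number from compound 3 to compound 4 (0.33 log units; beyond the scatter) is expected for compound 4. The estimate for compound 4 in this assay is 500 nM, with a range from 120 nM to 2500 nM.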

Compound 4, half-maximal inhibitory concentration: 500 nM
Beside the measured number, compound 4's estimate shows no gap at the digits printed, and the stated range covers the measured number.
By their numbers in this assay, from the lowest: compounds 2 and 4 (each within the scatter of the next); then compound 3.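

In this assay, this position accepts a much larger group: benzyloxy, with 8 heavy atoms and an added aromatic ring, replaces methyl with a 2.2-fold lower number from compound 3 to compound 4 (0.33 log units; beyond the scatter). Replacing chloro with benzyloxy gives a 2.0-fold higher number from compound 2 to compound 4 (0.30 log units; within the scatter), so these two very different groups cannot be told apart here, and group size alone does not set the number. On these data alone, whether the oxygen or the added ring of benzyloxy matters remains open, as does how an amine or a carboxylic acid would fare here. The unsubstituted compound 1 offers no firm baseline: the several entries of compound 1 in this assay, 480 nM; 10300 nM; 350 nM (3 entries)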